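A few compounds are considered here, and "the series" means these few. Any claim that something is new, unique, unknown or untested is made for them only; others in the source may bear on it.

Working notes on the series.

Compound 1 `CCCCCCCCCCCC(=O)OC[C@H](CSC[C@@H](N)C(=O)NCCCC(C)(C)CO)OC(=O)CCCCCCCCCCC` gives the highest number of the three measured in an assay on HEK293 cells for agonist activity at Toll-like receptor 2 (Homo sapiens) (on this read-out higher numbers stand for an effect only at larger amounts of compound and lower numbers for an effect already at smaller amounts), 30700 nM. Compound 2 `CCCCCCCCCCCC(=O)OC[C@H](CSC[C@@H](N)C(=O)NC(C)c1ccccc1)OC(=O)CCCCCCCCCCC` gives 9900 nM in this assay, and compound 3 `CCCCCCCCCCCC(=O)OC[C@H](CSC[C@@H](N)C(=O)NC(CC)COC)OC(=O)CCCCCCCCCCC` gives 71.8 nM. The two measured steps that leave compound 1 both lower the number: a 3.1-fold lower number from compound 1 to compound 2 (0.49 log units; beyond the scatter), and a 430-fold lower number from compound 1 to compound 3 (2.63 log units; beyond the scatter). Between the other two measured compounds, a 140-fold lower number from compound 2 to compound 3 (2.14 log units; beyond the scatter).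

Compound 4 `CCCCCCCCCCCC(=O)OC[C@H](CSC[C@@H](N)C(=O)NCCOCCOCCOCCC(=O)O)OC(=O)CCCCCCCCCCC` differs from compound 1 at the same amide-type nitrogen side of the core: 2-(2-(2-carboxyethoxy)ethoxy)ethoxy in place of 2-(hydroxymethyl)-2-methylpropyl on a saturated chain carbon, two bonds along the chain from an amide-type nitrogen. Going by the values given here, no measured step replaces this part of the chain with a group of this kind, so neither measured step bears on it closely; both only show that compound 1 is the weakest starting point here and that changes at this nitrogen have moved the number in one direction so far. On that footing a modest lowering, a 3.8-fold lower number from compound 1 to compound 4 (0.58 log units; beyond the scatter), is expected in this assay, with wide uncertainty. Compound 4 is therefore estimated at 8000 nM, in a range from 800 nM to 60000 nM.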

Compound 4, half-maximal effective concentration: 900 nM
Compound 4: middle estimate off by 8.9-fold (0.95 log units), on the high side, and the stated range covers the measured number.
By their numbers in this assay, from the lowest: compound 3; then compound 4; then compound 2; then compound 1.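

In this assay, the change on a saturated chain carbon, two bonds along the chain from an amide-type nitrogen, gives a 34-fold lower number from compound 1 to compound 4 (1.53 log units; beyond the scatter). So the number at this side of the core also responds to a change further out along the chain, not only to replacing the whole group on the nitrogen, and 2-(2-(2-carboxyethoxy)ethoxy)ethoxy, with 12 heavy atoms including 5 oxygens, is compatible with a lower number than the 6-atom 2-(hydroxymethyl)-2-methylpropyl. No supporting measurement is available to explain this step.

The compounds shown leave open whether the terminal carboxylic acid or the ether oxygens of the chain carry the step. A methyl ester or a primary alcohol at the chain end, or a shorter chain with fewer ethoxy units, would separate these parts.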